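Acetyl to hydrogen on the ring nitrogen, compound 2 to 3

The source may report more compounds than this note shows. Statements on the series, on what has been measured and on what is new or still open speak of the compounds shown alone.

Notes on a short series sharing one core. Compound 1 `COc1cccc(-c2oc3ccc(NC(C)=O)cc3c(=O)c2O)c1` is measured in an ADME assay on THP-1 cells (Homo sapiens) for cytotoxicity, read by flow cytometry and propidium iodide staining, with a stated time of 72 h (a lower number here means a stronger inhibitor, a higher number a weaker inhibitor), at 50000 nM. Compound 2 `CC(=O)Nc1ccc2oc(-c3ccc(F)cc3)c(O)c(=O)c2c1` is measured in this assay at 26000 nM. Going by the values given here, the one step between them, a 1.9-fold lower number from compound 1 to compound 2 (0.28 log units; within the scatter), puts the two within the scatter, so compound 2 and compound 1 cannot be ranked against each other on these numbers; compound 2 simply has the lower of the two values as read.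

Compound 3 `Nc1ccc2oc(-c3ccc(F)cc3)c(O)c(=O)c2c1` has not been measured. It differs from compound 2 as follows: hydrogen in place of acetyl on a nitrogen on an aromatic ring. Among the compounds with values here, the only measured step concerns a swap of the aryl group on an aromatic carbon and does not touch the nitrogen where compound 3 changes, so no step in hand bears on this change. The series therefore gives no basis for expecting a shift beyond the scatter in either direction in this assay.

For compound 3 the estimate is 26000 nM, with a range from 9000 nM to 75000 nM. The expected step is no change at the digits printed from compound 2 to compound 3 (within the scatter), taken as within the scatter.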

Compound 3, half-maximal inhibitory concentration: 4000 nM
Compound 3: middle estimate off by 6.5-fold (0.81 log units), on the high side; the whole stated range lies above it.
By their numbers in this assay, from the lowest: compound 3; then compounds 2 and 1 (each within the scatter of the next).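

Going by these compounds alone, the step of a 6.5-fold lower number from compound 2 to compound 3 (0.81 log units; beyond the scatter) in this assay is the first to lie beyond the scatter, and it falls at the nitrogen on an aromatic ring rather than at the aryl group. It shows that going from acetamido to amino can move the number in this assay, and that the free amino form reads lower than its acetamido partner, something the aryl swap could not show, as a 1.9-fold lower number from compound 1 to compound 2 (0.28 log units; within the scatter) stays within the scatter. Nothing available here bears on why the number moves at this nitrogen.

From the compounds shown here alone, it remains open whether the same change at the nitrogen gives a step of similar size with 3-methoxyphenyl on the aromatic carbon instead of 4-fluorophenyl, since a single pair cannot show whether the two positions act independently. Going by these compounds, it is also open whether a small alkyl group such as methyl on the nitrogen, a longer acyl chain such as propionyl or a methanesulfonyl group would read like the amino compound, like the acetamido compound or somewhere in between.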